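Carboxy to tetrazolyl on the shared core

A few compounds are considered here, and "the series" means these few. Any claim that something is new, unique, unknown or untested is made for them only; others in the source may bear on it.

Compound 1 `N=C(N)Nc1ccc(C(=O)Oc2ccc(CC(=O)O)n3ncnc23)cc1` and compound 2 `N=C(N)Nc1ccc(C(=O)Oc2ccc(CC(=O)O)n3ccnc23)cc1` have both been run in an ADME assay on MDCK cells (Canis lupus familiaris) for permeability, in the apical to basolateral direction; a lower number here means that the compound crosses the layer more slowly, a higher number that the compound crosses the layer faster. Compound 1 gives 1.53 10^-6 cm/s. Compound 2 gives 1.48 10^-6 cm/s, and the two numbers lie within the usual scatter of each other, so neither stands apart. Compound 3 `N=C(N)Nc1ccc(C(=O)Oc2ccc(Cc3nn[nH]n3)n3ncnc23)cc1` is not yet measured. It differs from compound 1 in one place: 2H-tetrazol-5-yl in place of carboxy on a saturated chain carbon bound to an aromatic carbon. Among the measured compounds shown here, no measured pair shows this change, so nothing here calibrates it. The expected step of a 1.2-fold higher number from compound 1 to compound 3 (0.07 log units; within the scatter) is small, in no clear direction, within the scatter. Compound 3 is therefore estimated at 1.8 10^-6 cm/s, with a range from 0.7 10^-6 cm/s to 4.5 10^-6 cm/s.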

Compound 3, apparent permeability: 1.45 10^-6 cm/s
The estimate for compound 3 lay 1.2-fold (0.09 log units) above the measured number, and the stated range covers the measured number.
By their numbers in this assay, from the lowest: compounds 3, 2 and 1 (each within the scatter of the next).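

In this assay the exchange of carboxy for 2H-tetrazol-5-yl on a saturated chain carbon bound to an aromatic carbon now has a measured size: a 1.1-fold lower number from compound 1 to compound 3 (0.02 log units; within the scatter). This position therefore takes the larger five-membered aromatic ring, with its added hydrogen-bond acceptors, without a step beyond the scatter on the core of compound 1. Nothing measured gives a reason for this result. From the compounds shown here alone, whether a primary amine or a longer chain ending in a carboxylic acid would behave alike at this position stays open. So does the same exchange on the core of compound 2.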